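A few compounds are considered here, and "the series" means these few. Any claim that something is new, unique, unknown or untested is made for them only; others in the source may bear on it.

Compounds 1, 2 and 3 share one core and were all tested in a functional assay on cells (Cancer cell lines, Homo sapiens) for cytotoxicity, read by sulforhodamine B assay, with a stated time of 48 h; a higher number here means a weaker inhibitor of growth, a lower number a stronger inhibitor of growth. Compound 1 `COc1ccc(OC)c(-c2cc(-c3ccc(Cl)cc3)nn2-c2ccc(S(=O)(=O)NC(C)=O)cc2)c1` gives 70200 nM in this assay. Compound 2 `Oc1ccc(O)c(-c2cc(-c3ccccc3)nn2-c2ccccc2)c1` gives 75700 nM, and compound 3 `Oc1ccc(O)c(-c2cc(-c3ccc(Cl)cc3)nn2-c2ccccc2)c1` gives 41100 nM. The number for compound 3 lies within the usual scatter of both of the others, so none of the three can be told apart on these data. Going by the values given here, the one single-point step that was measured, a 1.8-fold lower number from compound 2 to compound 3 (0.27 log units; within the scatter), changes a different part of the molecule and says nothing directly about the change now in question.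

Compound 4 `NS(=O)(=O)c1ccc(-n2nc(-c3ccc(Cl)cc3)cc2-c2cc(O)ccc2O)cc1` differs from compound 3 by sulfamoyl in place of hydrogen on an aromatic carbon. Among the compounds with values here, no measured pair shows this change on its own; compound 1 carries a related but larger group on the same ring together with other differences, so its value cannot be read as a step. Within the data shown here, with no step bearing on it, the expectation for compound 4 is a change no larger than the scatter, a 1.0-fold lower number from compound 3 to compound 4 (0.01 log units; within the scatter), giving an estimated 40000 nM with a range from 15000 nM to 100000 nM.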

Compound 4, concentration for total growth inhibition: 54500 nM
The estimate for compound 4 lay 1.4-fold (0.13 log units) below the measured number, and the stated range covers the measured number.
By their numbers in this assay, from the lowest: compounds 3, 4, 1 and 2 (each within the scatter of the next).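

Going by these compounds alone, the change from phenyl to 4-sulfamoylphenyl gives the first reading of a single change on this ring, with a 1.3-fold higher number from compound 3 to compound 4 (0.12 log units; within the scatter) in this assay and so no change that can be told from the scatter. Sulfamoyl, para to a large group, is therefore tolerated here in the limited sense that its four heavy atoms leave compound 4 indistinguishable from compound 3 on these data. Nothing measured here bears on why the step is this small.

The compounds shown leave open whether another group in the same place, such as an amine, a carboxylic acid or a longer chain, would move the number beyond the scatter. They also leave open whether sulfamoyl would read the same way if other parts of the shared core were changed.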